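A few compounds are considered here, and "the series" means these few. Any claim that something is new, unique, unknown or untested is made for them only; others in the source may bear on it.

Compound 1 `N=C(NCc1ccc(O)cc1)[C@@H]1CCC(=O)N1Cc1ccccc1[N+](=O)[O-]` gives 20% in a functional assay on SH-SY5Y cells (Homo sapiens) for cytotoxicity, read by MTT assay, with stated times of 8 h, 30 min and 12 h, tested at 0.05 uM; on this read-out lower numbers stand for a weaker effect and higher numbers for a stronger effect at the one concentration tested. Compound 2 `COc1ccc(CNC(=N)[C@@H]2CCC(=O)N2Cc2ccccc2[N+](=O)[O-])cc1` gives 18.1% in this assay. Compound 3 `N=C(NCc1ccc(O)cc1)[C@@H]1CCC(=O)N1Cc1ccc([N+](=O)[O-])cc1` gives 25.9% in this assay.

Compound 2 differs from compound 1 by methyl in place of hydrogen on an oxygen on an aromatic ring, and that change made a step of a number 1.9 percentage points lower from compound 1 to compound 2 (within the scatter). The cores of compound 1 and compound 3 differ by 4-nitrophenyl in place of 2-nitrophenyl on a saturated chain carbon bound to an amide-type nitrogen in a ring, a step of a number 5.9 percentage points higher from compound 1 to compound 3 (within the scatter). Compound 4 `COc1ccc(CNC(=N)[C@@H]2CCC(=O)N2Cc2ccc([N+](=O)[O-])cc2)cc1` is not yet measured; it differs from compound 3 by methyl in place of hydrogen on an oxygen on an aromatic ring, the same change as from compound 1 to compound 2, at the same place. Because the earlier step of a number 1.9 percentage points lower from compound 1 to compound 2 (within the scatter) stayed within the scatter, compound 4 is expected to sit close to compound 3, with an estimated step of a number 1.9 percentage points lower from compound 3 to compound 4 (within the scatter). The estimate for compound 4 in this assay is 24%, expected to fall between 14% and 34%.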

Compound 4, a percentage reported as activity, at one concentration (the size of the read-out at that concentration, not a potency): 14.3%
Beside the measured number, compound 4's estimate is 9.7 percentage points above it; the measured number falls inside the stated range.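

In this assay, methyl in place of hydrogen on the oxygen gave a number 11.6 percentage points lower from compound 3 to compound 4 (beyond the scatter), while 4-nitrophenyl in place of 2-nitrophenyl gave a number 3.8 percentage points lower from compound 2 to compound 4 (within the scatter). For the compounds shown here, the hydroxy to methoxy change thus passes beyond the scatter on only one of the two cores, yet this does not show that its effect depends on the core, nor that it carries over unchanged: the same change on two cores in this assay, a number 1.9 percentage points lower (within the scatter) from compound 1 to compound 2 and a number 11.6 percentage points lower (beyond the scatter) from compound 3 to compound 4, 9.7 percentage points apart, within the scatter of two such steps. The same caution applies to the nitrophenyl change: the same change on two cores in this assay, a number 5.9 percentage points higher (within the scatter) from compound 1 to compound 3 and a number 3.8 percentage points lower (within the scatter) from compound 2 to compound 4, 9.7 percentage points apart, within the scatter of two such steps.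

The compounds shown leave open how an ethoxy group or an amine in place of the hydroxy group would read. Each comparison also rests on just two cores at a single concentration.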